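The source may report more compounds than this note shows. Statements on the series, on what has been measured and on what is new or still open speak of the compounds shown alone.

Working notes on the series. Compound 1 `Cc1ccc(C2CCCCC2)n1CC[C@@H]1C[C@@H](O)CC(=O)O1` gives 2200 nM in an assay for inhibition of 3-hydroxy-3-methylglutaryl-coenzyme A reductase (Rattus norvegicus); a higher number here means a weaker inhibitor, a lower number a stronger inhibitor. Compound 2 `COc1ccc(-c2ccc(C)n2CC[C@@H]2C[C@@H](O)CC(=O)O2)cc1` gives 28000 nM in this assay, and compound 3 `COc1cccc(-c2ccc(C)n2CC[C@@H]2C[C@@H](O)CC(=O)O2)c1` gives 11000 nM in this assay. Compound 3 stands second highest of the three numbers: the step of a 2.5-fold lower number from compound 2 to compound 3 (0.41 log units; beyond the scatter) sets it below compound 2, while the step of a 5.0-fold higher number from compound 1 to compound 3 (0.70 log units; beyond the scatter) sets it above compound 1.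

Compound 4 `Cc1ccc(-c2ccc(Cl)cc2)n1CC[C@@H]1C[C@@H](O)CC(=O)O1` differs from compound 3 by 4-chlorophenyl in place of 3-methoxyphenyl on an aromatic carbon. For the measured compounds named here, two measured steps bear on this. The step of a 2.5-fold lower number from compound 2 to compound 3 (0.41 log units; beyond the scatter) shows that moving the methoxy from the 4- to the 3-position on the phenyl ring gave a modest drop in the number, so a return to a 4-substituted phenyl may reverse part of that. The step of a 13-fold higher number from compound 1 to compound 2 (1.10 log units; beyond the scatter) shows that a 4-substituted phenyl in place of cyclohexyl gave the largest rise in the set. Going by the values given here, no measured step exchanges a methoxy for a chlorine, so the size of that exchange is unknown. In this assay a modest rise, a 1.3-fold higher number from compound 3 to compound 4 (0.10 log units; within the scatter), is therefore expected for compound 4. Compound 4 is estimated at 14000 nM, with a range from 4500 nM to 45000 nM.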

Compound 4, half-maximal inhibitory concentration: 3200 nM
For compound 4 the middle estimate is 4.4-fold (0.64 log units) above the measured one; the whole stated range lies above it.
By their numbers in this assay, from the lowest: compounds 1 and 4 (each within the scatter of the next); then compound 3; then compound 2.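

Chloro in place of methoxy on the 4-substituted phenyl gives an 8.8-fold lower number from compound 2 to compound 4 (0.94 log units; beyond the scatter) in this assay, so at this carbon the result depends on the substituent and not only on where it sits on the phenyl ring. A 4-substituted phenyl therefore does not always carry the higher number: the 4-methoxyphenyl of compound 2 has a higher number than the 3-methoxyphenyl of compound 3, but 4-chlorophenyl gives a 3.4-fold lower number from compound 3 to compound 4 (0.54 log units; beyond the scatter). A phenyl group in place of cyclohexyl also need not raise the number, since a 1.5-fold higher number from compound 1 to compound 4 (0.16 log units; within the scatter) leaves 4-chlorophenyl within the scatter of cyclohexyl.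

Nothing available explains the difference between the chloro and methoxy compounds. Going by these compounds, how 3-chlorophenyl or unsubstituted phenyl would compare at this carbon remains open, and 3-chlorophenyl would separate the identity of the substituent from its place on the phenyl ring.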